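The compounds below may be only part of what the source reports. "The series", "measured", "known", "first", "only" and "open" are said of these compounds alone.

Measured in a functional assay on DU-145 cells (Homo sapiens) for cytotoxicity, read by trypan blue exclusion, with a stated time of 96 h; a lower number here means a stronger inhibitor, a higher number a weaker inhibitor:
- compound 1 `COc1cc(OC)c(/C=C/S(=O)(=O)Nc2ccc(OC)c([N+](=O)[O-])c2)c(OC)c1`: 2500 nM
- compound 2 `COc1ccc(NS(=O)(=O)/C=C/c2c(OC)cc(OCCCC(=O)O)cc2OC)cc1[N+](=O)[O-]`: 100000 nM

Going by the values given here, of these two, compound 2 has the higher number, at 100000 nM, and compound 1 is the only neighbour to compare it with. Compound 3 `COc1ccc(NS(=O)(=O)/C=C/c2c(OC)cc(OCCCC(=O)O)cc2OC)cc1O` keeps the chain of compound 2 but has hydroxy in place of nitro on an aromatic carbon. Among the compounds with values here, the one measured step, a 40-fold higher number from compound 1 to compound 2 (1.60 log units; beyond the scatter), is large and beyond the scatter, but it concerns the chain and not this position, so it bears only indirectly. Within the data shown here, no measured compound carries the hydroxy group, so the data say little about this swap. Since compound 3 retains the chain, a number in the high range of compound 2 remains expected, with a modest move downward at most. The expected change is a 2.5-fold lower number from compound 2 to compound 3 (0.40 log units; beyond the scatter). For compound 3 the estimated value is 40000 nM, with an expected range of 8000 nM to 100000 nM.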

Compound 3, half-maximal inhibitory concentration: 10000 nM
Compound 3: middle estimate off by 4.0-fold (0.60 log units), on the high side; the range from low to high includes it.
By their numbers in this assay, from the lowest: compound 1; then compound 3; then compound 2.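

In this assay the swap of nitro for hydroxy on this aromatic carbon, ortho to a methoxy group, gives a 10-fold lower number from compound 2 to compound 3 (1.00 log units; beyond the scatter) and so lies beyond the scatter. Going by these compounds alone, the earlier step concerned only the chain, so this is the first sign that the group at this position also moves the number. The move occurs with the chain of compound 2 kept in place, which shows that the chain does not fix the number on its own. Nothing at hand explains the size of this step.

Open, on these data alone, is whether an amine or a chlorine on this aromatic carbon would follow hydroxy or nitro. Also open, as far as these compounds go, is whether the same swap would give a step of like size in compound 1, which lacks the carboxylic acid chain.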